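The compounds below may be only part of what the source reports. "The series", "measured", "known", "first", "only" and "open" are said of these compounds alone.

Measured so far:
compound 1, `Fc1ccccc1Cn1nc(-c2ccccn2)c2cccnc21`: 4800 nM
compound 2, `CCCCCc1cnc(-c2nn(Cc3ccccc3F)c3ncccc23)nc1N`: 200000 nM

In a functional assay (aorta) with Oryctolagus cuniculus as the target (a higher number here means a weaker inhibitor, a lower number a stronger inhibitor), compound 1 gives 4800 nM, while compound 2 gives 200000 nM, the higher of the two numbers and so the weaker inhibitor of the pair. Among the measured compounds shown here, no pair of measured compounds differs in a single place, so the two values simply stand side by side without a computed step.

Compound 3, `Nc1nc(-c2nn(Cc3ccccc3F)c3ncccc23)ncc1F`, is yet to be measured in this assay. It differs from compound 2 in one place: fluoro in place of pentyl on an aromatic carbon. For the measured compounds named here, nothing measured so far shows what fluoro in place of pentyl does on this core, and compound 1 has a different substitution pattern altogether, so no direction can be read from the data. The step of a 2.0-fold lower number from compound 2 to compound 3 (0.30 log units; within the scatter) is expected to be small, a modest move toward a lower number that need not exceed the scatter. For compound 3 the value expected in this assay is 100000 nM, with a range from 20000 nM to 500000 nM.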

Compound 3, half-maximal inhibitory concentration: 478000 nM
Estimate against measurement, compound 3: 4.8-fold (0.68 log units) below, and the stated range covers the measured number.
By their numbers in this assay, from the lowest: compound 1; then compound 2; then compound 3.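

In this assay, fluoro in place of pentyl on the aromatic carbon ortho to an amino group gives a 2.4-fold higher number from compound 2 to compound 3 (0.38 log units; beyond the scatter), a modest step, so removing the pentyl chain brings no gain in strength at this position. Replacing pyridin-2-yl with 4-amino-5-fluoropyrimidin-2-yl gives a 100-fold higher number from compound 1 to compound 3 (2.00 log units; beyond the scatter), a large step, so this exchange costs far more than the choice between fluoro and pentyl on the same ring. No measurement at hand explains either step.

The large step combines the ring change, the amino group and the fluoro, and the compounds shown do not separate their contributions. Also open, from the compounds shown here alone, is how this position responds to a methyl or methoxy group, or to plain hydrogen, and whether any such group recovers strength.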